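N-Methylation of the Ring Amine in an Inactive Biphenyl Analogue

This account rests on a few compounds, and the source may have more. Where it says the series, first, only, none or still open, it means among the compounds named here.

Compound 1 `c1cncc(N2C[C@H]3CNC[C@H]3C2)c1` gives 0.12 nM in an assay on membranes from brain for displacement of a labelled ligand from Neuronal acetylcholine receptor; alpha4/beta2 (Rattus norvegicus); a higher number here means a weaker inhibitor, a lower number a stronger inhibitor. Compound 2 `c1ccc(-c2cncc(N3C[C@H]4CNC[C@H]4C3)c2)cc1` gives 0.16 nM in this assay, and the step of a 1.3-fold higher number from compound 1 to compound 2 (0.12 log units; within the scatter) stays within the scatter. Compound 3 `c1ccc(-c2ccc(N3C[C@H]4CNC[C@H]4C3)cc2)cc1` yields only a limit in this assay, > 10000 nM. Compound 3 therefore stands at the limit of > 10000 nM in this assay, at which 1 of the 3 values shown sits, and has no number of its own. Compound 4 `CN1C[C@@H]2CN(c3ccc(-c4ccccc4)cc3)C[C@@H]2C1` carries the change (methyl in place of hydrogen on an amine nitrogen in a ring). For the measured compounds named here, no measured step touches the amine nitrogen in the ring; the single step seen, a 1.3-fold higher number from compound 1 to compound 2 (0.12 log units; within the scatter), concerns an aromatic carbon and lies within the scatter. With compound 3 already at the limit, compound 4 is expected to stay at or beyond that limit, the nominal step being a step that the limit leaves unreadable from compound 3 to compound 4. The estimate for compound 4 in this assay is 20000 nM, with a range from 5000 nM to 100000 nM.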

Compound 4, inhibition constant: > 100000 nM
Compound 4: only a limit was reported (the forecaster's own chance of this, stated with the estimate: 80%); middle value at least 5.0-fold (0.69 log units) away from the limit.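

For the compounds shown here, compound 3 and compound 4 are both reported only as limits in this assay, and no step between them can be read. Open: what methyl in place of hydrogen on the ring amine nitrogen does to a measurable value.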